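Anilide Variation on a Shared Core against A549 Proliferation

The compounds below may be only part of what the source reports. "The series", "measured", "known", "first", "only" and "open" are said of these compounds alone.

Compound 1 `O=C(CN1CCN(c2cc3c(cc2F)c(=O)c(C(=O)O)cn3C2CC2)CC1)Nc1ccccc1` — > 100000 nM
Compound 2 `COc1ccc(NC(=O)CN2CCN(c3cc4c(cc3F)c(=O)c(C(=O)O)cn4C3CC3)CC2)cc1` — 24800 nM
Compound 3 `COc1cc(NC(=O)CN2CCN(c3cc4c(cc3F)c(=O)c(C(=O)O)cn4C3CC3)CC2)cc(OC)c1OC` — > 100000 nM

In a functional assay on A549 cells (Homo sapiens) for antiproliferative activity, read by BrdU incorporation, with a stated time of 24 h (on this read-out lower numbers stand for stronger inhibition and higher numbers for weaker inhibition), compound 3 stands only at the assay limit, > 100000 nM. Compound 1 likewise sits at the limit, > 100000 nM. Compound 2 gives a real number, 24800 nM. The step of an at least 4.0-fold lower number from compound 1 to compound 2 (0.60 log units; beyond the scatter) is therefore readable, while a step that the two limits leave unreadable from compound 1 to compound 3 is not. The step of an at least 4.0-fold higher number from compound 2 to compound 3 (0.60 log units; beyond the scatter) is readable only as far as the limit of > 100000 nM in this assay, at which 2 of the 3 values shown sit, allows. Compound 4 `Cc1ccc(NC(=O)CN2CCN(c3cc4c(cc3F)c(=O)c(C(=O)O)cn4C3CC3)CC2)cc1` differs from compound 3 by 4-methylphenyl in place of 3,4,5-trimethoxyphenyl on an amide-type nitrogen. Among the measured compounds shown here, the only readable comparisons, an at least 4.0-fold lower number from compound 1 to compound 2 (0.60 log units; beyond the scatter) and an at least 4.0-fold higher number from compound 2 to compound 3 (0.60 log units; beyond the scatter), place a single para substituent better than none or three. For compound 4 a step of an at least 2.0-fold lower number from compound 3 to compound 4 (0.30 log units; that floor lies within the scatter) is expected. Compound 4 is estimated at 50000 nM, between 15000 nM and 150000 nM.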

Compound 4, half-maximal inhibitory concentration: 23600 nM
The estimate for compound 4 lay 2.1-fold (0.33 log units) above the measured number, within the range that was stated.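

On the amide-type nitrogen, 4-methylphenyl reads the same as 4-methoxyphenyl, with a 1.1-fold lower number from compound 2 to compound 4 (0.02 log units; within the scatter), so a single substituent there need not carry oxygen. The methyl group also repeats the gain over phenyl, with an at least 4.2-fold lower number from compound 1 to compound 4 (0.62 log units; beyond the scatter), and over 3,4,5-trimethoxyphenyl, with an at least 4.2-fold lower number from compound 3 to compound 4 (0.62 log units; beyond the scatter). Both of these steps are only floors, since each starts from a value that is a limit of the assay: the limit of > 100000 nM in this assay, at which 2 of the 4 values shown sit.

On these data alone, whether another kind of group on that ring, such as an amine or a carboxylic acid, would keep this level of inhibition stays open. Also open, as far as these compounds go, is how far the true values of compound 1 and compound 3 lie beyond the limit.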